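The compounds below may be only part of what the source reports. "The series", "measured", "known", "first", "only" and "open" are said of these compounds alone.

Measured so far in an ADME assay (liver) for metabolic stability, with Liver microsome (Rattus norvegicus) as the target, using microsomes and NADPH, with a stated time of 30 min; a lower number here means slower removal, a higher number faster removal of the compound:
compound 1, `CC#C[C@H]1CN(S(=O)(=O)c2ccc(N)nc2)CCN1c1ccc(C(O)(CC#N)C(F)(F)F)cc1`: 57 mL.min-1.g-1
compound 2, `CC#C[C@H]1CN(S(=O)(=O)c2ccc(N)nc2)CCN1c1ncc(C(O)(C(F)(F)F)C(F)(F)F)s1`: 34 mL.min-1.g-1
compound 3, `CC#C[C@H]1CN(S(=O)(=O)c2ccc(N)nc2)CCN1c1ncc(C(O)(C(F)(F)F)C(F)(F)F)cn1`: 28 mL.min-1.g-1

Compound 1 gives the highest of the three numbers in this assay. Its gap to compound 2 lies within the scatter, so no order between these two is claimed; its gap to compound 3 lies beyond the scatter, so compound 3 is removed more slowly than compound 1. Compound 4, `CC#C[C@H]1CN(S(=O)(=O)c2ccc(N)nc2)CCN1c1ccc(S(=O)(=NC)C(F)(F)F)cc1`, has not yet been measured. It differs from compound 1 in one place: a group of 8 heavy atoms (2 carbon, 1 nitrogen, 1 oxygen, 3 fluorine, 1 sulfur; no ring) in place of a group of 9 heavy atoms (4 carbon, 1 nitrogen, 1 oxygen, 3 fluorine; no ring), on an aromatic carbon. For the measured compounds named here, no step between two measured compounds that differ in a single place is available, so nothing among the measured compounds sets a size for this change. The three measured numbers sit in a narrow band, and a step no larger than the scatter is expected here, with no clear direction. For compound 4 the expected number in this assay is 45 mL.min-1.g-1, range 20 mL.min-1.g-1 to 100 mL.min-1.g-1. The step that this estimate means is expected to be a 1.3-fold lower number from compound 1 to compound 4 (0.10 log units; within the scatter).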

Compound 4, intrinsic clearance in microsomes: 257 mL.min-1.g-1
The estimate for compound 4 lay 5.7-fold (0.76 log units) below the measured number; the whole stated range lies below it.
By their numbers in this assay, from the lowest: compounds 3, 2 and 1 (each within the scatter of the next, the first and the last beyond it); then compound 4.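

For the compounds shown here, this change gives the first step between two compounds that differ in one place. On an aromatic carbon, para to a large group, the exchange of these two groups gives in this assay a 4.5-fold higher number from compound 1 to compound 4 (0.65 log units; beyond the scatter), so the number at this position is sensitive to the group placed there. Nothing measured here accounts for this step, and the exchange alters several counted features at once, so no single feature can be singled out.

Still open, from the compounds shown here alone, is which part of the entering group goes with the higher number, which a sulfone or a simple trifluoromethyl group at the same position would help to separate. Also open, going by these compounds, is whether the same exchange on the cores of compound 2 and compound 3 would give a step of similar size.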